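Swapping the trifluoromethylbenzyl arm for a cyclopropylmethyl group

The source may hold more compounds than are shown below. What is called first, only, known or untested is meant among the compounds shown, and "the series" means these compounds.

Compound 1 `N#Cc1cccc(COc2ccc(-c3cc(CN4CCN(Cc5ccc(C(F)(F)F)cc5)CC4)no3)cc2)c1` is the starting point. In a functional assay on MCF7 cells (Homo sapiens) for antiproliferative activity, read by sulforhodamine B assay, with a stated time of 72 h (a lower number here means a stronger inhibitor, a higher number a weaker inhibitor), compound 1 gives 800 nM. Its closest relative, compound 2 `COc1ccc(COc2ccc(-c3cc(CN4CCN(Cc5ccc(C(F)(F)F)cc5)CC4)no3)cc2)cc1`, gives 1300 nM in this assay; the change was a 1.6-fold higher number from compound 1 to compound 2 (0.21 log units; within the scatter), so the two compounds cannot be told apart on these numbers, and compound 1 cannot be called the more potent of the pair.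

Compound 3 `N#Cc1cccc(COc2ccc(-c3cc(CN4CCN(CC5CC5)CC4)no3)cc2)c1` has not been measured. It differs from compound 1 at the other end of the shared core: cyclopropyl in place of 4-(trifluoromethyl)phenyl on a saturated chain carbon bound to an amine nitrogen in a ring. Among the measured compounds shown here, the only measured step concerns the group on the saturated chain carbon bound to an oxygen on an aromatic ring, and it was within the scatter, so nothing measured bears on this change. For compound 3 a step of a 1.6-fold higher number from compound 1 to compound 3 (0.21 log units; within the scatter) is expected, with wide uncertainty. Compound 3 is estimated at 1300 nM, in the range 400 nM to 5000 nM.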

Compound 3, half-maximal inhibitory concentration: 3500 nM
The estimate for compound 3 lay 2.7-fold (0.43 log units) below the measured number; the range from low to high includes it.
By their numbers in this assay, from the lowest: compounds 1 and 2 (each within the scatter of the next); then compound 3.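

At the other end of the shared core, the group on the saturated chain carbon bound to an amine nitrogen in a ring has a readable effect in this assay. Among the compounds shown here, replacing 4-(trifluoromethyl)benzyl with cyclopropylmethyl gives a 4.4-fold higher number from compound 1 to compound 3 (0.64 log units; beyond the scatter), whereas the only earlier step, on the saturated chain carbon bound to an oxygen on an aromatic ring, stayed within the scatter. This single swap exchanges the 10 heavy atoms of 4-(trifluoromethyl)phenyl, with their six-membered aromatic ring, for the 3 heavy atoms of cyclopropyl, and no measurement here explains why the number rises.

Going by these compounds, it remains open whether the aromatic ring or the trifluoromethyl group matters more, and a plain benzyl group at this position would help separate the two. A longer chain such as n-butyl would show how a non-aromatic group of another size behaves here.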